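Swapping bromo for chloro in compound 2

The source may report more compounds than this note shows. Statements on the series, on what has been measured and on what is new or still open speak of the compounds shown alone.

Of the compounds shown here, three sharing one core have been measured in a functional assay on A549 cells (Homo sapiens) for antiproliferative activity, read by MTT assay, with a stated time of 48 h; on this read-out lower numbers stand for stronger inhibition and higher numbers for weaker inhibition. Compound 1 `Cc1ccc(-c2nnc(NC(=O)/C=C/c3ccc(C(F)(F)F)cc3)s2)cc1` gives 1.61 ug/mL, compound 2 `O=C(/C=C/c1ccc(C(F)(F)F)cc1)Nc1nnc(-c2ccc(Br)cc2)s1` gives 4.68 ug/mL, and compound 3 `O=C(/C=C/c1ccc(F)cc1)Nc1nnc(-c2ccc(Br)cc2)s1` gives 2.83 ug/mL. Compound 2 therefore sits at the weak end of this small set, level with compound 3 within the scatter and clearly apart from compound 1.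

The next compound, compound 4 `O=C(/C=C/c1ccc(C(F)(F)F)cc1)Nc1nnc(-c2ccc(Cl)cc2)s1`, differs from compound 2 in a single substituent, with 4-bromophenyl becoming 4-chlorophenyl: chloro in place of bromo on an aromatic carbon. Chloro takes the place of bromo on an aromatic carbon, para to a large group.

For the measured compounds named here, two measured steps bear on this change. The closer one is a 2.9-fold higher number from compound 1 to compound 2 (0.46 log units; beyond the scatter), a modest change in which bromo replaced methyl at the same place. The other is a 1.7-fold lower number from compound 2 to compound 3 (0.22 log units; within the scatter), in which fluoro replaced trifluoromethyl elsewhere in the molecule. Neither step involves chloro, so neither gives a firm direction, and no large change is expected in this assay. The expected change is a 1.2-fold lower number from compound 2 to compound 4 (0.09 log units; within the scatter), with no real step beyond the scatter. For compound 4 the estimated value is 3.8 ug/mL, with an expected range of 1.9 ug/mL to 7.5 ug/mL.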

Compound 4, half-maximal inhibitory concentration: 3.09 ug/mL
Estimate against measurement, compound 4: 1.2-fold (0.09 log units) above; measured number inside the range.
By their numbers in this assay, from the lowest: compounds 1, 3, 4 and 2 (each within the scatter of the next, the first and the last beyond it).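

Putting chloro in place of bromo at this position, para to a large group, leaves the number in this assay within the scatter (a 1.5-fold lower number from compound 2 to compound 4 (0.18 log units; within the scatter)), so this assay does not separate these two halogens here. Chloro in place of methyl also stays within the scatter (a 1.9-fold higher number from compound 1 to compound 4 (0.28 log units; within the scatter)), whereas the earlier step with bromo in place of methyl lay beyond it (a 2.9-fold higher number from compound 1 to compound 2 (0.46 log units; beyond the scatter)), which places compound 4 within reach of both neighbours and leaves methyl and bromo as the only pair at this position that the assay separates, and only modestly. Nothing available here explains why these substituents give such similar numbers.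

From the compounds shown here alone, all three substituents compared at this position are small and uncharged, so it remains open whether a very different group there, such as an amine, a carboxylic acid or a longer alkyl chain, would keep the number in this range or shift it well beyond the scatter. Going by these compounds, it is also open whether chloro would behave the same way with fluoro in place of trifluoromethyl at the other end of the molecule, as in compound 3.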